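This account rests on a few compounds, and the source may have more. Where it says the series, first, only, none or still open, it means among the compounds named here.

Measured compounds:
Compound 1, `CCCc1nc(-c2ccccc2)c(CNCCN2CCN(c3ccc(OC)cc3)CC2)o1`: 9200 nM
Compound 2, `CCCc1nc(-c2ccccc2)c(CNCCN2CCN(c3ccc(C(F)(F)F)cc3)CC2)o1`: 1300 nM

In an assay on HEK293 cells for inhibition of Voltage-dependent T-type calcium channel subunit alpha-1G (Homo sapiens), read by patch clamp (on this read-out higher numbers stand for weaker inhibition and lower numbers for stronger inhibition), compound 2 gives the lowest of the two numbers recorded so far, with compound 1 the nearest at 9200 nM. For the measured compounds named here, the only step measured is a 7.1-fold lower number from compound 1 to compound 2 (0.85 log units; beyond the scatter). Compound 3, `CCCc1nc(-c2ccccc2)c(CNCCN2CCN(c3cccc(C)c3C)CC2)o1`, has not been measured. It differs from compound 2 in one place: 2,3-dimethylphenyl in place of 4-(trifluoromethyl)phenyl on an amine nitrogen in a ring. Going by the values given here, no measured pair has the same change, so the step of a 7.1-fold lower number from compound 1 to compound 2 (0.85 log units; beyond the scatter) bears on it only indirectly, as a sign that the group on this ring nitrogen moves the number well beyond the scatter. Without a closer precedent, compound 3 is expected to land somewhat higher than compound 2, a step of a 2.3-fold higher number from compound 2 to compound 3 (0.36 log units; beyond the scatter), with wide uncertainty in either direction. The estimate for compound 3 in this assay is 3000 nM, with a range from 800 nM to 12000 nM.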

Compound 3, half-maximal inhibitory concentration: 1710 nM
Compound 3: the middle estimate sits 1.8-fold (0.24 log units) above what was measured, and the stated range covers the measured number.
By their numbers in this assay, from the lowest: compounds 2 and 3 (each within the scatter of the next); then compound 1.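

In this assay, the change of 4-(trifluoromethyl)phenyl to 2,3-dimethylphenyl on the ring nitrogen gives a 1.3-fold higher number from compound 2 to compound 3 (0.12 log units; within the scatter) and so does not separate the two groups. The change from 4-methoxyphenyl to 2,3-dimethylphenyl gives a 5.4-fold lower number from compound 1 to compound 3 (0.73 log units; beyond the scatter) and shows that the gap to compound 1 does not depend on trifluoromethyl alone, since two differently substituted phenyl groups now stand apart from 4-methoxyphenyl. Nothing available here explains why these groups give these numbers.

The compounds shown leave open whether a phenyl group is needed on this ring nitrogen at all, as an acetyl or a simple methyl there would test. They also leave open whether a single methyl on the phenyl ring matches the two methyls of compound 3 in this read-out.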